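Swapping Chloro for Methyl in a Cytotoxicity Series

The source may hold more compounds than are shown below. What is called first, only, known or untested is meant among the compounds shown, and "the series" means these compounds.

Compound 1 `Cn1nnnc1SCC(=O)N/N=C/c1ccc(Cl)cc1` and compound 3 `COc1cccc(/C=N/NC(=O)CSc2nnnn2C)c1` share their core with compound 2 `Cn1nnnc1SCC(=O)N/N=C/c1ccccc1Cl`. In an ADME assay on NIH3T3 cells (Mus musculus) for cytotoxicity, read by XTT assay, with a stated time of 24 h (on this read-out lower numbers stand for stronger inhibition and higher numbers for weaker inhibition), compound 1 gives 2100000 nM. In this assay compound 3 gives 600000 nM. For compound 2 only a limit of the assay is known, > 10000000 nM, so compound 2 stands at the limit of > 10000000 nM in this assay, at which 1 of the 3 values shown sits. Compound 4 `Cc1ccccc1/C=N/NC(=O)CSc1nnnn1C` differs from compound 2 by methyl in place of chloro on an aromatic carbon. For the measured compounds named here, no measured pair shows the size of this change, so the step in this assay is expected to be small, either within the scatter or modestly toward stronger inhibition. Compound 4 is therefore estimated to give 7000000 nM, within 2000000 nM to 20000000 nM. That expectation amounts to a step of an at least 1.4-fold lower number from compound 2 to compound 4 (0.15 log units; that floor lies within the scatter).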

Compound 4, half-maximal inhibitory concentration: 6320000 nM
The estimate for compound 4 lay 1.1-fold (0.04 log units) above the measured number; measured number inside the range.
By their numbers in this assay, from the lowest: compound 3; then compound 1; then compound 4. At a limit, above all of these: compound 2.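

With methyl in place of chloro on an aromatic carbon ortho to a large group, this position now carries a true number in this assay rather than only a limit. The change amounts to an at least 1.5-fold lower number from compound 2 to compound 4 (0.19 log units; that floor lies within the scatter). That size is only a floor, and the full step cannot be read, for compound 2 stands at a limit: the limit of > 10000000 nM in this assay, at which 1 of the 4 values shown sits.

Whether the position tolerates a very different group remains open, since the compounds shown hold no amine or carboxylic acid there. Also open, going by these compounds, is whether a longer chain would give a clearly lower number than methyl.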